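A few compounds are considered here, and "the series" means these few. Any claim that something is new, unique, unknown or untested is made for them only; others in the source may bear on it.

Two compounds have been measured so far:
compound 1, `CC(C)c1ccc(-n2nc(-c3ccc(C(F)(F)F)cc3O)nc2-c2ccccc2O)cc1`, 108%;
compound 2, `Oc1cc(C(F)(F)F)ccc1-c1nc(-c2ccccc2O)n(-c2ccc(F)cc2F)n1`, 97.9%.

In a functional assay on PC-12 cells (Rattus norvegicus) for cytotoxicity, read by MTT assay, with stated times of 2 h and 24 h, tested at 10 uM (a lower number here means a weaker effect, a higher number a stronger effect of the compound at the concentration tested), compound 1 gives 108%, the higher of the two numbers, and compound 2 gives 97.9%. Among the compounds with values here, the single measured step, a number 10.1 percentage points lower from compound 1 to compound 2 (beyond the scatter), comes from a swap of the group on the aromatic nitrogen of the shared core. Compound 3, `Oc1cc(C(F)(F)F)ccc1-c1nc(-c2ccccc2O)n(-c2cc(F)cc(F)c2)n1`, has not yet been measured; relative to compound 1 the change is 3,5-difluorophenyl in place of 4-isopropylphenyl on an aromatic nitrogen. The step from compound 1 to compound 2 bears directly on this: both changes remove the 4-isopropylphenyl from the same aromatic nitrogen and put a difluorophenyl there, and that step was modest. A step of similar size and the same direction is therefore expected in this assay for compound 3, namely a number 10 percentage points lower from compound 1 to compound 3 (within the scatter). Compound 3 is estimated at 98%, within a range from 85% to 112%.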

Compound 3, a percentage reported as activity, at one concentration (the size of the read-out at that concentration, not a potency): 106%
Compound 3: the middle estimate sits 8 percentage points below what was measured, and the stated range covers the measured number.
By their numbers in this assay, from the lowest: compounds 2, 3 and 1 (each within the scatter of the next, the first and the last beyond it).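

In this assay, 3,5-difluorophenyl in place of 4-isopropylphenyl on the aromatic nitrogen gives a number 2 percentage points lower from compound 1 to compound 3 (within the scatter), so a difluorophenyl at this position does not necessarily separate from the 4-isopropylphenyl compound, as the step to compound 2 alone might have suggested. Placing the two fluorines as in 3,5-difluorophenyl rather than 2,4-difluorophenyl gives a number 8.1 percentage points higher from compound 2 to compound 3 (within the scatter), so these two difluorophenyl groups cannot be told apart here. Only compounds 1 and 2 lie beyond the scatter of each other, and that single gap is too slight to support a trend at this nitrogen. Nothing available accounts for these numbers. From the compounds shown here alone, it remains open whether a phenyl ring bearing an amine or a carboxylic acid, or a butyl chain in place of the ring, would give a different read-out at this nitrogen.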